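Amino on the methoxyphenyl ring of compound 2

The source may report more compounds than this note shows. Statements on the series, on what has been measured and on what is new or still open speak of the compounds shown alone.

Compound 1 `COc1cc(-n2c(-c3ccc(Cl)cc3)cn(C(C)=O)c2=O)cc(OC)c1OC` gives > 50000 nM (a limit)
Compound 2 `COc1ccc(-c2cn(C(C)=O)c(=O)n2-c2cc(OC)c(OC)c(OC)c2)cc1` gives 200 nM (a number)

Among the measured compounds shown here, in a functional assay on K562 cells (Homo sapiens) for cytotoxicity, read by MTT assay, with a stated time of 48 h (on this read-out higher numbers stand for weaker inhibition and lower numbers for stronger inhibition), compound 2 stands at 200 nM as the only number available. The entry for compound 1 is a limit and not a number. Compound 3 `COc1ccc(-c2cn(C(C)=O)c(=O)n2-c2cc(OC)c(OC)c(OC)c2)cc1N` differs from compound 2 by amino in place of hydrogen on an aromatic carbon and so turns 4-methoxyphenyl to 3-amino-4-methoxyphenyl. For the measured compounds named here, one measured step bears on this: the large one an at least 250-fold lower number from compound 1 to compound 2 (2.39 log units; beyond the scatter) with methoxy in place of chloro on an aromatic carbon, beyond the scatter. Compound 3 keeps that methoxy group, so the gain of the step of an at least 250-fold lower number from compound 1 to compound 2 (2.39 log units; beyond the scatter) is expected to stay. Only a small further change is expected in this assay toward a lower number. The expected change is a 2.0-fold lower number from compound 2 to compound 3 (0.30 log units; within the scatter) and lies near the scatter. Compound 3 is estimated at 100 nM (range 20 nM to 500 nM).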

Compound 3, half-maximal inhibitory concentration: 500 nM
Compound 3: middle estimate off by 5.0-fold (0.70 log units), on the low side; low and high end bracket the measured number.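

In this assay, placing an amino group on an aromatic carbon ortho to a methoxy group does not add to the gain that came with the methoxy group, and the change gives a 2.5-fold higher number from compound 2 to compound 3 (0.40 log units; beyond the scatter). This shows that the position is not indifferent to substitution, although the cost is small beside an at least 100-fold lower number from compound 1 to compound 3 (2.00 log units; beyond the scatter), so the 3-amino-4-methoxyphenyl ring still retains a large advantage over the 4-chlorophenyl ring. The size of that larger step remains a bound, since compound 1 is recorded only as a limit and not as a number: the limit of > 50000 nM in this assay, at which 1 of the 3 values shown sits.

The compounds shown leave open whether the rise belongs to the amino group itself or would follow any group at this place. A hydroxyl group, a methyl group or an acetamide here would help separate these readings.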